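Swapping the amine on the thiocarbonyl: compound 3 to compound 4

The source may hold more compounds than are shown below. What is called first, only, known or untested is meant among the compounds shown, and "the series" means these compounds.

Measured compounds:
- compound 1 `Nc1ccccc1NC(=O)c1ccc(CSC(=S)N2CCN(C(c3ccccc3)c3ccccc3)CC2)cc1`: 9.8%
- compound 2 `Nc1ccccc1NC(=O)c1ccc(CSC(=S)N2CCc3ccccc32)cc1`: 44%
- compound 3 `CN(C(=S)SCc1ccc(C(=O)Nc2ccccc2N)cc1)c1cccnc1`: 46.1%

In a functional assay on MGC-803 cells (Homo sapiens) for antiproliferative activity, read by CCK-8 assay, with a stated time of 72 h, tested at 2 uM (on this read-out higher numbers stand for a stronger effect at the one concentration tested and lower numbers for a weaker effect), compound 3 gives the highest of the three numbers, though compound 2 sits within the scatter of it, while compound 1 lies far lower. Compound 4 `CC1CCCCN1C(=S)SCc1ccc(C(=O)Nc2ccccc2N)cc1` is not yet measured; it differs from compound 3 by 2-methylpiperidin-1-yl in place of methyl(pyridin-3-yl)amino on a thiocarbonyl carbon. Going by the values given here, the one measured step at that same position, a number 2.1 percentage points higher from compound 2 to compound 3 (within the scatter), changed little, so a change of amine there need not move the read-out. Compound 1, however, carries a much larger amine at that place and is far weaker, which widens the uncertainty. A step of about a number 6.1 percentage points lower from compound 3 to compound 4 (within the scatter) is therefore expected, essentially none beyond the scatter. Compound 4 is estimated at 40%, between 18% and 60%.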

Compound 4, a percentage reported as inhibition, at one concentration (the size of the read-out at that concentration, not a potency): 64.4%
Estimate against measurement, compound 4: 24.4 percentage points below, outside the stated range (above it).
By their numbers in this assay, from the lowest: compound 1; then compounds 2 and 3 (each within the scatter of the next); then compound 4.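

In this assay, the choice of amine on the thiocarbonyl carbon clearly can matter: a number 18.3 percentage points higher from compound 3 to compound 4 (beyond the scatter) and a number 20.4 percentage points higher from compound 2 to compound 4 (beyond the scatter), whereas the earlier step between compound 2 and compound 3 stayed within the scatter. The step to compound 4 exchanges a six-membered aromatic ring for a six-membered non-aromatic one, but nothing measured here accounts for the rise. Still open, going by these compounds, is whether the methyl group of 2-methylpiperidin-1-yl counts, which plain piperidin-1-yl would test. Morpholin-4-yl would show how an oxygen atom in that ring changes the read-out.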